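A few compounds are considered here, and "the series" means these few. Any claim that something is new, unique, unknown or untested is made for them only; others in the source may bear on it.

Working notes on the series. Three compounds have so far been run in an assay on CHO-K1 cells for activation of DNA damage-inducible transcript 3 protein (Homo sapiens), read by a luciferase reporter; on this read-out higher numbers stand for an effect only at larger amounts of compound and lower numbers for an effect already at smaller amounts. Compound 1 `O=C(Nc1ccc(S(=O)(=O)N2CCC(Cl)CC2)cc1)c1ccc([N+](=O)[O-])o1` returns a number, 800 nM. For compound 2 `CC1(C)CCN(S(=O)(=O)c2ccc(NC(=O)c3cccc([N+](=O)[O-])c3)cc2)CC1` the result is only a limit of the assay, > 80000 nM. For compound 3 `Cc1ccc(C(=O)Nc2ccc(S(=O)(=O)N3CCOCC3)cc2)o1` the result is likewise a limit, > 80000 nM. Among the compounds with values here, compound 2 therefore stands at the shared limit with compound 3, while compound 1 is the single member with a measured value; no pair of measured compounds differs in one place, so no step can be drawn, and the only fixed point is the limit of > 80000 nM in this assay, at which 2 of the 3 values shown sit.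

Compound 4 `CC1(C)CCN(S(=O)(=O)c2ccc(NC(=O)c3ccc(C(F)(F)F)o3)cc2)CC1` has not yet been measured. It differs from compound 2 in one place: 5-(trifluoromethyl)furan-2-yl in place of 3-nitrophenyl on a carbonyl carbon. Compound 1 and compound 3 each differ from compound 4 in more than one place, so their values only show the spread the series can cover in this assay. Compound 2 sits at a limit. The step from compound 2 to compound 4 is expected as an at least 3.2-fold lower number from compound 2 to compound 4 (0.50 log units; beyond the scatter), toward smaller amounts, but its size cannot be read off and may not clear the scatter. Compound 4 is estimated at 25000 nM, within 3000 nM to 80000 nM, with a real chance that it also returns only a limit.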

Compound 4, concentration for half-maximal activity: > 80000 nM
Compound 4 was reported as a limit (the forecaster's own chance of this, stated with the estimate: 50%); at least 3.2-fold (0.50 log units) between middle value and limit.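

Compound 4 returns only a limit, as compound 2 does, so no step can be read between compound 2 and compound 4: the limit of > 80000 nM in this assay, at which 3 of the 4 values shown sit.

The compounds shown leave open whether 5-(trifluoromethyl)furan-2-yl in place of 3-nitrophenyl on a carbonyl carbon changes the read-out at all, and how compound 2 and compound 4 compare.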